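The source may report more compounds than this note shows. Statements on the series, on what has been measured and on what is new or still open speak of the compounds shown alone.

Measured in an ADME assay on HEL cells (Homo sapiens) for cytotoxicity, with a stated time of 3 days; on this read-out lower numbers stand for higher toxicity in this test and higher numbers for lower toxicity in this test:
- compound 1 `Cc1cc(-n2ccc3cccnc32)cn2c(CSCCc3ccccc3)cnc12`: 20 ug/mL
- compound 2 `Cc1cc(-c2ccoc2)c2ncc(CSCCc3ccccc3)n2c1`: 100 ug/mL
- compound 3 `Cc1cc(N2CCCC2)c2ncc(CSCc3ccccc3)n2c1`: a limit, >= 20 ug/mL

Compound 2 stands at the highest of the two numbers shown in this assay. Its nearest neighbour in value is compound 1, which sits a step lower, a gap beyond the usual scatter of repeated measurements. For compound 3 the assay reports only a limit, not a number; this is the limit of >= 20 ug/mL in this assay, at which 1 of the 3 values shown sits, where one of the three values shown sits.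

Compound 4 `Cc1cc(N2CCCC2=O)c2ncc(CSCCc3ccccc3)n2c1` has not yet been measured in this assay. It differs from compound 2 in one place: 2-oxopyrrolidin-1-yl in place of furan-3-yl on an aromatic carbon. Among the compounds with values here, no step between measured compounds covers this change, so its size in this assay cannot be read from the data. Compound 3, carrying a pyrrolidin-1-yl at the same place, gives only a limit, which leaves the direction open.

The step from compound 2 to compound 4 in this assay is expected to be modest and downward, a 2.0-fold lower number from compound 2 to compound 4 (0.30 log units; within the scatter), within or just beyond the scatter. Compound 4 is estimated to give 50 ug/mL in this assay, with a range from 20 ug/mL to 100 ug/mL.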

Compound 4, minimum cytotoxic concentration: 20 ug/mL
For compound 4 the middle estimate is 2.5-fold (0.40 log units) above the measured one; the range from low to high includes it.
By their numbers in this assay, from the lowest: compounds 1 and 4 (each within the scatter of the next); then compound 2.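

In this assay this aromatic carbon does not tolerate every five-membered ring equally: 2-oxopyrrolidin-1-yl in place of furan-3-yl gives a 5.0-fold lower number from compound 2 to compound 4 (0.70 log units; beyond the scatter). Within the data shown here, this is the only readable step at this place, and it swaps a five-membered aromatic ring for a five-membered non-aromatic ring with a carbonyl, while the counts of hydrogen-bond donors and acceptors stay the same. A single step cannot show which part of the change carries the difference.

Going by these compounds, compound 3, with pyrrolidin-1-yl at this place, also differs from compound 4 in a second place and gives only a limit: the limit of >= 20 ug/mL in this assay, at which 1 of the 4 values shown sits. Also open is whether an open-chain amine such as dimethylamino or a carboxylic acid at this carbon would stay nearer compound 2 or compound 4 in this assay.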